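A few compounds are considered here, and "the series" means these few. Any claim that something is new, unique, unknown or untested is made for them only; others in the source may bear on it.

Of the compounds shown here, three sharing one core have been measured. Compound 1 `CCCCNc1nc(-c2ccccc2)c(Cc2c(O)ccc3ccccc23)c(=O)[nH]1` gives 1900 nM in a functional assay on RT-112 cells (Homo sapiens) for antiproliferative activity, read by MTT assay, with a stated time of 3 h; a higher number here means a weaker inhibitor, a lower number a stronger inhibitor. Compound 2 `CCN(CC)c1nc(-c2ccccc2)c(Cc2c(O)ccc3ccccc23)c(=O)[nH]1` gives 32200 nM, and compound 3 `C#CCNc1nc(-c2ccccc2)c(Cc2c(O)ccc3ccccc23)c(=O)[nH]1` gives 91200 nM, the weakest of the three, as the steps of a 48-fold higher number from compound 1 to compound 3 (1.68 log units; beyond the scatter) and a 2.8-fold higher number from compound 2 to compound 3 (0.45 log units; beyond the scatter) show. Compound 4 `O=c1[nH]c(NCCO)nc(-c2ccccc2)c1Cc1c(O)ccc2ccccc12` differs from compound 3 by hydroxymethyl in place of ethynyl on a saturated chain carbon bound to a nitrogen on an aromatic ring. The step that bears on this position is a 48-fold higher number from compound 1 to compound 3 (1.68 log units; beyond the scatter), which shows that the group on that chain carbon moves the number strongly. Going by the values given here, no measured compound carries a hydroxymethyl there, so the direction is uncertain, but since the ethynyl of compound 3 gave the highest number, compound 4 is expected to land lower, by a 7.6-fold lower number from compound 3 to compound 4 (0.88 log units; beyond the scatter). The estimate for compound 4 is 12000 nM, within 2500 nM to 60000 nM.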

Compound 4, half-maximal inhibitory concentration: 7200 nM
Estimate against measurement, compound 4: 1.7-fold (0.22 log units) above; low and high end bracket the measured number.
By their numbers in this assay, from the lowest: compound 1; then compound 4; then compound 2; then compound 3.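

In this assay the swap of ethynyl for hydroxymethyl on this chain carbon gives a 13-fold lower number from compound 3 to compound 4 (1.10 log units; beyond the scatter) and recovers much of what the propargylamino group lost. Replacing diethylamino with (2-hydroxyethyl)amino gives a 4.5-fold lower number from compound 2 to compound 4 (0.65 log units; beyond the scatter), yet hydroxy in place of ethyl gives a 3.8-fold higher number from compound 1 to compound 4 (0.58 log units; beyond the scatter), so the butylamino group of compound 1 still has the lowest number of the four. No evidence here gives a reason for these shifts. Still open, going by these compounds, is how an amine or a carboxylic acid at the chain end, or a longer chain carrying the hydroxy, would compare with compound 1 and compound 4.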